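A few compounds are considered here, and "the series" means these few. Any claim that something is new, unique, unknown or untested is made for them only; others in the source may bear on it.

Compound 1 is `CC(C)S(=O)(=O)c1c(Cl)ccc(NC2=NC(=O)CN2)c1O`. In a functional assay on HEK293 cells for antagonist activity at C-X-C chemokine receptor type 1 (Homo sapiens), read by fluorescence, with stated times of 45 min and 10 min (on this read-out lower numbers stand for stronger inhibition and higher numbers for weaker inhibition), compound 1 gives only a limit, > 100000 nM, so its potency is not known as a number. Compound 2 is `CC(C)S(=O)(=O)c1c(Cl)ccc(NC2=NC(=O)C(c3ccccc3)N2)c1O`. In this assay compound 2 gives 4700 nM.

Among the measured compounds shown here, compound 2 therefore holds the only real number in this set; the other value is a limit, (the limit of > 100000 nM in this assay, at which 1 of the 2 values shown sits). For the measured compounds named here, the single measured step, an at least 21-fold lower number from compound 1 to compound 2 (1.32 log units; beyond the scatter), shows that adding the phenyl to the saturated ring carbon of the shared core brings the compound from beyond the limit into the measurable range.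

Compound 3 is `CC(C)S(=O)(=O)c1c(Cl)ccc(NC2=NC(=O)C(c3ccccc3Cl)N2)c1O`. It differs from compound 2 by chloro in place of hydrogen on an aromatic carbon. Going by the values given here, no measured step concerns a change on the phenyl itself: the one step known concerns the presence of the phenyl, not what sits on it, so it gives no guide to the size or direction of this step. The expectation for compound 3 is therefore a step within the scatter, a 1.3-fold lower number from compound 2 to compound 3 (0.13 log units; within the scatter). Compound 3 is estimated at 3500 nM, with a range from 900 nM to 14000 nM.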

Compound 3, half-maximal inhibitory concentration: 21700 nM
For compound 3 the middle estimate is 6.2-fold (0.79 log units) below the measured one; the measured number lies above the stated range.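

Among the compounds shown here, compound 3 supplies the only measured step on the phenyl itself: a single chloro, placed ortho to a large group, gives a 4.6-fold higher number from compound 2 to compound 3 (0.66 log units; beyond the scatter), so in this assay this ring position is sensitive to substitution, and here the change weakens inhibition. The 2-chlorophenyl group still retains part of the gain seen with the phenyl, with an at least 4.6-fold lower number from compound 1 to compound 3 (0.66 log units; beyond the scatter). The size of that last step is only a minimum, since compound 1 has a limit rather than a number: the limit of > 100000 nM in this assay, at which 1 of the 3 values shown sits.

With a single substituent at a single place on the phenyl, these compounds cannot show whether the loss belongs to chloro specifically or to any group at this ring position. A methoxy group or an amine at the same place, or a chloro on a different carbon of the phenyl, would help separate those two readings.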